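A few compounds are considered here, and "the series" means these few. Any claim that something is new, unique, unknown or untested is made for them only; others in the source may bear on it.

Measured compounds:
compound 1, `COCCO/N=C/c1c(N)ncnc1Oc1ccc2[nH]c(C)cc2c1F`: 387 nM
compound 2, `CO/N=C/c1c(N)ncnc1Oc1ccc2c(ccn2C)c1`: 749 nM

In a functional assay on HCT-116 cells (Homo sapiens) for antiproliferative activity (a higher number here means a weaker inhibitor, a lower number a stronger inhibitor), compound 1 gives 387 nM, the lower of the two numbers recorded so far. Compound 2 gives 749 nM in this assay, and the gap between the two lies within the scatter of repeated measurements, so neither can be called the stronger inhibitor. Compound 3, `Cc1cc2c(F)c(Oc3ncnc(N)c3/C=N/OCCO)ccc2[nH]1`, is the compound still to be measured. It differs from compound 1 in one place: hydrogen in place of methyl on an oxygen on a saturated carbon. Read one bond further out, the 2-methoxyethyl group of compound 1 becomes a 2-hydroxyethyl group, and the rest of the structure is kept. Within the data shown here, no pair of measured compounds shows this change, so the expectation rests only on how small the change is, a single heavy atom removed at the end of a chain. The step is expected to stay within the usual scatter, with a lean toward a slightly higher number, a 1.2-fold higher number from compound 1 to compound 3 (0.09 log units; within the scatter). Compound 3 is thus expected to give about 480 nM, in a range from 160 nM to 1450 nM.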

Compound 3, half-maximal inhibitory concentration: 323 nM
Beside the measured number, compound 3's estimate is 1.5-fold (0.17 log units) above it, and the stated range covers the measured number.
By their numbers in this assay, from the lowest: compounds 3, 1 and 2 (each within the scatter of the next, the first and the last beyond it).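

In this assay, the change from 2-methoxyethyl to 2-hydroxyethyl gives a 1.2-fold lower number from compound 1 to compound 3 (0.08 log units; within the scatter), so on this core the methyl on the oxygen at the end of the chain can be exchanged for hydrogen without a step that stands out from the scatter. This is the first pair among the compounds shown that differs in one place, and it gives the first direct reading of this position, which compound 1 and compound 2 could not give because they differ in more than one place. No supporting measurement bears on this result, and the pair alone cannot say why the step is so small.

The compounds shown leave open whether the same holds for groups of a different kind at the end of this chain, such as an amine or a carboxylic acid in place of the hydroxy, or for a longer chain carrying the hydroxy. They also leave open whether the step would stay this small on a different core, such as that of compound 2, since this change is read on one pair only.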